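The source may hold more compounds than are shown below. What is called first, only, known or untested is meant among the compounds shown, and "the series" means these compounds.

Within the data shown here, compound 3 `COC1Cc2c(csc2-c2ccccc2)C2(CCN(Cc3ccccc3)CC2)O1` gives 1 nM in an assay on membranes from brain for displacement of a labelled ligand from Sigma non-opioid intracellular receptor 1 (Cavia porcellus), read by scintillation counting, with a stated time of 120 min (a higher number here means a weaker inhibitor, a lower number a stronger inhibitor), the lowest of the three numbers measured so far. Compound 2 `O=[N+]([O-])c1ccc(-c2scc3c2CCOC32CCN(Cc3ccccc3)CC2)cc1` gives 1.7 nM in this assay, a gap from compound 3 that lies within the scatter, so no order between the two can be claimed. Compound 1 `c1ccc(CN2CCC3(CC2)OCCc2c3csc2-c2ccccc2)cc1` gives 4.5 nM in this assay; the step of a 4.5-fold lower number from compound 1 to compound 3 (0.65 log units; beyond the scatter) is beyond the scatter, as is the step of a 2.6-fold lower number from compound 1 to compound 2 (0.42 log units; beyond the scatter).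

Compound 4 `COC1Cc2c(csc2-c2ccc(C#N)cc2)C2(CCN(Cc3ccccc3)CC2)O1` is not yet measured. It differs from compound 3 by cyano in place of hydrogen on an aromatic carbon. The measured step that bears on this is a 2.6-fold lower number from compound 1 to compound 2 (0.42 log units; beyond the scatter), a substituent entering the same phenyl ring on a parent that otherwise lacks the methoxy group. Among the measured compounds shown here, no measured pair shows an aromatic substituent entering on top of the methoxy-bearing core, so the expectation rests on that single step alone.

The expected result is a modest lowering, a 1.8-fold lower number from compound 3 to compound 4 (0.26 log units; within the scatter), in this assay. For compound 4 the estimate in this assay is 0.55 nM, with a range from 0.2 nM to 1.5 nM.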

Compound 4, inhibition constant: 0.25 nM
Compound 4: middle estimate off by 2.2-fold (0.34 log units), on the high side, and the stated range covers the measured number.
By their numbers in this assay, from the lowest: compound 4; then compounds 3 and 2 (each within the scatter of the next); then compound 1.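

Notes on the series: in this assay the step of a 4.0-fold lower number from compound 3 to compound 4 (0.60 log units; beyond the scatter) shows that the phenyl ring still gives a lower number on taking a substituent when the methoxy group is already present. The only earlier aromatic step a 2.6-fold lower number from compound 1 to compound 2 (0.42 log units; beyond the scatter) came from nitro entering on the parent without the methoxy group, so the position para to a large group now gives a lower number with two different groups on two parents, and no compound shown goes against this. No measurement shown explains the effect of the cyano group.

As far as these compounds go, whether the same lowering holds for an amine, a carboxylic acid or a fluorine at this position stays open. Also open, from the compounds shown here alone, is what cyano does on the parent without the methoxy group.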